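From dimethylamino to chloro at the assay limit

The source may report more compounds than this note shows. Statements on the series, on what has been measured and on what is new or still open speak of the compounds shown alone.

Measured so far in an ADME assay on CEMx174 cells (Homo sapiens) for cytotoxicity; on this read-out lower numbers stand for higher toxicity in this test and higher numbers for lower toxicity in this test:
Compound 1 `CCC1=C(C(=O)OCC2CCCCC2)C(c2cccc(N)c2)NC(=O)N1` gives > 10000 nM as a limit
Compound 2 `CCC1=C(C(=O)OCC2CCCCC2)C(c2ccc(N(C)C)cc2)NC(=O)N1` gives > 10000 nM as a limit

Compound 2 stands only at a limit, so it offers no number to start from. With the limit of > 10000 nM in this assay, at which 2 of the 2 values shown sit, as the whole record, the measured compounds give no reading of their own beyond that limit. Compound 3 `CCC1=C(C(=O)OCC2CCCCC2)C(c2ccc(Cl)cc2)NC(=O)N1` carries chloro in place of dimethylamino on an aromatic carbon, para to a large group, a difference counted as chloro in place of dimethylamino on an aromatic carbon against compound 2. Within the data shown here, the only measured step is a step that the two limits leave unreadable from compound 1 to compound 2 and so gives no size to carry over. No step beyond the scatter is therefore expected in this assay and no direction can be named. The expected step is a step that the limit leaves unreadable from compound 2 to compound 3 by this estimate. Compound 3 is expected near 20000 nM with an estimated range from 8000 nM to 50000 nM and may well report only a limit.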

Compound 3, half-maximal cytotoxic concentration: > 10000 nM
Compound 3: only a limit was reported; the forecaster's own chance of this, stated with the estimate: 80%; the middle value is on the limit's open side.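

In this assay no step can be read among compound 1, compound 2 and compound 3, since each reports only a limit: the limit of > 10000 nM in this assay, at which 3 of the 3 values shown sit.
The compounds shown leave open whether the 3-aminophenyl, 4-(dimethylamino)phenyl and 4-chlorophenyl groups differ at all in this read-out, and by how much.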